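The source may hold more compounds than are shown below. What is called first, only, known or untested is meant among the compounds shown, and "the series" means these compounds.

Working notes on the series, read in a functional assay on NALM-6 cells (Homo sapiens) for cytotoxicity, read by MTT assay, with a stated time of 46 h; a higher number here means a weaker inhibitor, a lower number a stronger inhibitor. Compound 1 `Cc1ccc(/C=C2\C(=O)c3ccccc3OC2c2ccccc2)cc1` is reported as > 1000000 nM, which is a limit of the assay and not a number. Compound 2 `O=C1/C(=C/c2ccc(Br)cc2)C(c2ccccc2)Oc2ccccc21` gives 6900 nM, and compound 3 `O=c1c(Cc2ccc([N+](=O)[O-])cc2)coc2ccccc12` gives 5000 nM. These two numbers lie within the usual scatter of each other, so compound 3 stands level with compound 2, and no order can be drawn between them.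

Compound 4 `O=c1c(Cc2ccc(F)cc2)coc2ccccc12` keeps the core of compound 3 and differs from it in one place: fluoro in place of nitro on an aromatic carbon. This puts fluoro in place of nitro on an aromatic carbon of a six-membered aromatic ring of carbon only, para to a large group. Within the data shown here, no measured pair isolates this change, so the size of the step cannot be read from the data. The expectation therefore rests on compound 3 at 5000 nM as the nearest anchor, and no shift beyond the scatter is firmly expected in this assay, with only a slight lean towards a higher number. The expected change is a 1.4-fold higher number from compound 3 to compound 4 (0.15 log units; within the scatter). For compound 4 the estimated half-maximal inhibitory concentration is 7000 nM, with an expected range of 2000 nM to 30000 nM.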

Compound 4, half-maximal inhibitory concentration in the NALM-6 assay: 8200 nM
The estimate for compound 4 lay 1.2-fold (0.07 log units) below the measured number; the measured number falls inside the stated range.
By their numbers in the NALM-6 assay, from the lowest: compounds 3, 2 and 4 (each within the scatter of the next). At a limit, above all of these: compound 1.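

In the NALM-6 assay compound 3 gives 5000 nM and compound 4 gives 8200 nM. In the NALM-6 assay, fluoro in place of nitro on an aromatic carbon of a six-membered aromatic ring of carbon only, para to a large group, gives a 1.6-fold higher number from compound 3 to compound 4 (0.21 log units; within the scatter). Among these compounds, this is the first step between compounds that differ in one place, and it shows that this position takes either group without a shift that can be told from the scatter. In a physicochemical assay for lipophilicity, read by HPLC (on this read-out higher numbers stand for higher lipophilicity and lower numbers for lower lipophilicity), compound 3 gives 3.93 and compound 4 gives 4.02. In the physicochemical assay the same change gives a number 0.09 log units higher from compound 3 to compound 4 (within the scatter), so this pair stays unseparated on both read-outs, and nothing in the data on hand bears on a cause for either step.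

Open, going by these compounds, is whether an amine, a carboxylic acid or a methoxy group on this aromatic carbon would stay level with nitro and fluoro, or whether any group here would move the number in the NALM-6 assay beyond the scatter. Also open, on these data alone, is how much of the level of compound 3 and compound 4 belongs to their shared core and how much to the group at this position, as the core of compound 2 differs from theirs in more than one place.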